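Swapping Ethyl for Fluoro on the Sulfonamide Aryl Ring

The compounds below may be only part of what the source reports. "The series", "measured", "known", "first", "only" and "open" are said of these compounds alone.

Measured compounds:
compound 1 `Cc1ccc(C)c(NS(=O)(=O)c2cccc(CCCCCCNC(=O)/C=C/c3cccnc3)c2)c1` — in an assay on isolated protein for inhibition of Nicotinamide phosphoribosyltransferase (Homo sapiens), read by WST assay, with stated times of 60 min, 5 min and 30 min, in the presence of a further agent that is not named here (on this read-out lower numbers stand for stronger inhibition and higher numbers for weaker inhibition), compound 1 gives 11.6 nM
compound 2 `CCc1ccc(NS(=O)(=O)c2cccc(CCCCCCNC(=O)/C=C/c3cccnc3)c2)cc1` — in this assay compound 2 gives 31.5 nM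

Going by the values given here, compound 2 stands highest of the two numbers in this assay; the only measured step, a 2.7-fold higher number from compound 1 to compound 2 (0.43 log units; beyond the scatter), was modest but beyond the scatter. Compound 3 `O=C(/C=C/c1cccnc1)NCCCCCCc1cccc(S(=O)(=O)Nc2ccc(F)cc2)c1` differs from compound 2 by fluoro in place of ethyl on an aromatic carbon. That measured step swapped a whole differently substituted ring, so it gives only a loose guide here. Compound 3 is expected to show a 1.3-fold higher number from compound 2 to compound 3 (0.10 log units; within the scatter), a step not beyond the scatter. The estimate for compound 3 is 40 nM, with a range from 15 nM to 110 nM.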

Compound 3, half-maximal inhibitory concentration: 9.2 nM
The estimate for compound 3 lay 4.3-fold (0.64 log units) above the measured number; the whole stated range lies above it.
By their numbers in this assay, from the lowest: compounds 3 and 1 (each within the scatter of the next); then compound 2.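

At this position on the sulfonamide aryl ring, a small change of substituent is enough to shift the result: fluoro in place of ethyl gives a 3.4-fold lower number from compound 2 to compound 3 (0.53 log units; beyond the scatter) for a swap of a single group. The 4-fluorophenyl ring, with one substituent, also performs on a par with the 2,5-dimethylphenyl ring, with a 1.3-fold lower number from compound 1 to compound 3 (0.10 log units; within the scatter) on that comparison. Nothing available here accounts for the shift.

Going by these compounds, whether the lower number comes from fluoro itself or from the loss of ethyl stays open. A plain phenyl ring, a 4-chlorophenyl ring or a 4-methoxyphenyl ring would help separate the two.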